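This account rests on a few compounds, and the source may have more. Where it says the series, first, only, none or still open, it means among the compounds named here.

In a physicochemical assay for lipophilicity, in phosphate buffer, measured as octanol-water partition, at pH 11.5 (a higher number here means a more lipophilic compound, a lower number a more polar compound), compound 1 (`CCCCCCCCCCCCNC(=N)NC(=N)Nc1ccc(Cl)cc1`) gives 7.13, compound 2 (`CCCCCCCCNC(=N)NC(=N)Nc1ccc(Cl)cc1`) gives 5.13 and compound 3 (`CCCNC(=N)NC(=N)Nc1ccc(Cl)cc1`) gives 2.63, the lowest of the three numbers and clearly apart from the other two. The next compound, compound 4 (`CCCCCCCCCCNC(=N)NC(=N)Nc1ccc(Cl)cc1`), departs from compound 3 by heptyl in place of hydrogen on a saturated chain carbon, three bonds along the chain from an amine nitrogen. Within the data shown here, two measured steps bear on this change. Putting hydrogen in place of butyl gave a number 2.00 log units lower from compound 1 to compound 2 (beyond the scatter), and putting hydrogen in place of pentyl, at the same place where heptyl now enters, gave a number 2.50 log units lower from compound 2 to compound 3 (beyond the scatter). Both steps are large, and both run downward as the chain is cut back. Among the measured compounds shown here, the change to compound 4 runs the opposite way and adds a group larger than that pentyl, so a large rise in this assay is expected, greater than the one seen between compound 3 and compound 2. The expected change is a number 3.50 log units higher from compound 3 to compound 4 (beyond the scatter). For compound 4 the estimated value is 6.13, with an expected range from 5.8 to 6.45.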

Compound 4, partition coefficient: 6.13
Compound 4: middle estimate and measured number agree at the digits printed; the measured number falls inside the stated range.
By their numbers in this assay, from the lowest: compound 3; then compound 2; then compound 4; then compound 1.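

Compound 4 fits the order of the chains in this assay, and none of the four compounds goes against that order. At three bonds along the chain from an amine nitrogen, heptyl gives a number 3.50 log units higher from compound 3 to compound 4 (beyond the scatter) and so a larger step than any earlier one at this place, while ethyl in place of hydrogen at eight bonds gives a number 1.00 log units higher from compound 2 to compound 4 (beyond the scatter) and hydrogen in place of ethyl on a saturated chain carbon gives a number 1.00 log units lower from compound 1 to compound 4 (beyond the scatter) as a step of the same size in the opposite direction. No measurement given here accounts for these step sizes.

The compounds shown leave open whether this order would continue with a chain longer than that of compound 1. They also leave open where a branched chain, or a chain ending in a hydroxyl or a carboxylic acid, would stand.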